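Ether chain swap on the glycine transporter series

The source may hold more compounds than are shown below. What is called first, only, known or untested is meant among the compounds shown, and "the series" means these compounds.

compound 1 `COc1ccc2c(c1)CN(C(=O)c1cc(S(C)(=O)=O)ccc1O[C@@H](C)C(F)(F)F)C2` — 180 nM
compound 2 `C[C@H](Oc1ccc(S(C)(=O)=O)cc1C(=O)N1Cc2cc(C(F)(F)F)cnc2C1)C(F)(F)F` — 50 nM
compound 3 `C[C@H](Oc1ccc(S(C)(=O)=O)cc1C(=O)N1Cc2cnc(C(F)(F)F)cc2C1)C(F)(F)F` — 132 nM

In an assay on CHO cells for inhibition of sodium- and chloride-dependent glycine transporter 1 (Homo sapiens), read by scintillation counting (a higher number here means that more compound is needed for the effect, a lower number that less compound is needed), compound 2 gives the lowest number of the three measured compounds; compound 3 and compound 1 both sit beyond the scatter above it. Among the compounds with values here, no pair of measured compounds differs in one place only, so no measured step is available.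

Compound 4 `CS(=O)(=O)c1ccc(OCCC(F)(F)F)c(C(=O)N2Cc3cc(C(F)(F)F)cnc3C2)c1` is the next analogue: 3,3,3-trifluoropropyl in place of 1-(trifluoromethyl)ethyl on an oxygen on an aromatic ring. The branched side chain with its defined stereocentre is replaced by a straight chain of the same atom count.

Within the data shown here, with no measured step of this kind, the expectation for compound 4 rests on the change alone; a loss beyond the scatter is expected from compound 2 to compound 4, a 3.2-fold higher number from compound 2 to compound 4 (0.51 log units; beyond the scatter). The estimate for compound 4 in this assay is 160 nM, within 50 nM to 600 nM.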

Compound 4, half-maximal effective concentration: 111 nM
Estimate against measurement, compound 4: 1.4-fold (0.16 log units) above; the range from low to high includes it.
By their numbers in this assay, from the lowest: compound 2; then compounds 4, 3 and 1 (each within the scatter of the next).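

In this assay the ether position now has its first measured step: a 2.2-fold higher number from compound 2 to compound 4 (0.35 log units; beyond the scatter) is modest but beyond the scatter. With the same heavy atoms on the oxygen, the 3,3,3-trifluoropropyl chain, which has no defined stereocentre, retains activity, while the arrangement of the chain still shifts the number. Nothing measured here bears on the reason for this step.

Open, as far as these compounds go, is whether the same swap gives a similar step on the cores of compound 1 and compound 3. Also open, from the compounds shown here alone, is how a longer chain, such as 4,4,4-trifluorobutyl, would read on this oxygen.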